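Methyl for methoxy on a second core: a toxicity estimate

This account rests on a few compounds, and the source may have more. Where it says the series, first, only, none or still open, it means among the compounds named here.

Measured so far, in the order of their numbers:
compound 1, `Cc1ccc2nc(-c3ccccn3)c(Nc3ccc(F)cc3)n2c1`, 9610 nM
compound 2, `COc1ccc2nc(-c3ccccn3)c(Nc3ccc(F)cc3)n2c1`, 4260 nM
compound 3, `COc1ccn2c(Nc3ccc(F)cc3)c(-c3ccccn3)nc2c1`, 4560 nM

All three values come from an ADME assay on THP-1 cells (Homo sapiens) for cytotoxicity; on this read-out lower numbers stand for higher toxicity in this test and higher numbers for lower toxicity in this test. Compound 2 and compound 3 are built from the same atoms joined differently; the difference between the two cores is not broken down here. Their values lie within the usual scatter of each other, so nothing can be said about an order between them.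

Within the core of compound 2, one change has been measured: methyl in place of methoxy on an aromatic carbon. The step is a 2.3-fold higher number from compound 2 to compound 1 (0.35 log units; beyond the scatter), a higher number that stands for lower toxicity in this assay.

Compound 4, `Cc1ccn2c(Nc3ccc(F)cc3)c(-c3ccccn3)nc2c1`, is not yet measured. It carries the same kind of change on the core of compound 3: methyl in place of methoxy on an aromatic carbon. The surroundings differ slightly in wording: in compound 4 the carbon is opposite the ring nitrogen, whereas in compound 1 it is two atoms from the ring nitrogen.

Because a 2.3-fold higher number from compound 2 to compound 1 (0.35 log units; beyond the scatter) was modest but beyond the scatter, compound 4 is expected to show a step of about a 2.1-fold higher number from compound 3 to compound 4 (0.32 log units; beyond the scatter). Accordingly compound 4 is estimated at 9500 nM, with a plausible range from 4500 nM to 20000 nM. This expectation rests on a single measured example, so it is held loosely.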

Compound 4, half-maximal cytotoxic concentration: 5900 nM
Compound 4: the middle estimate sits 1.6-fold (0.21 log units) above what was measured; the measured number falls inside the stated range.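

Methyl in place of methoxy on the core of compound 3 gives, in this assay, a 1.3-fold higher number from compound 3 to compound 4 (0.11 log units; within the scatter), a step too small to be told apart from the ordinary variation between repeated measurements. Set beside the earlier step on the core of compound 2, the new step does not stand apart from it: the same change on two cores in this assay, a 2.3-fold higher number (0.35 log units; beyond the scatter) from compound 2 to compound 1 and a 1.3-fold higher number (0.11 log units; within the scatter) from compound 3 to compound 4, 1.7-fold (0.24 log units) apart, within the scatter of two such steps The two results are therefore compatible with one shared effect of this change on both cores, but they do not show that the effect carries over at a fixed size, or that it lowers toxicity on every core, as only one of the two steps lies beyond the scatter and two pairs of compounds are a very small base for any rule.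

The compounds shown leave open how other groups at this place on the ring would read in this assay, for example a chlorine atom, an amine, a carboxylic acid or a longer chain such as ethoxy. They also leave open whether methyl in place of methoxy would give a clearer step on a third core, where a further matched pair could help settle how well the change transfers.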